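A Single Swap on the Sugar-Side Oxygen

The compounds below may be only part of what the source reports. "The series", "measured", "known", "first", "only" and "open" are said of these compounds alone.

Compound 1 `CCC/N=C(\S)OC[C@H]1OC(n2cnc3c(NC4CCOC4)ncnc32)[C@H](O)[C@@H]1O`: 50 nM
Compound 2 `CC(C)NC(=O)OC[C@H]1OC(n2cnc3c(NC4CCOC4)ncnc32)[C@H](O)[C@@H]1O`: 78 nM

For the measured compounds named here, in an assay on DDT1 cells (Cricetulus griseus) for binding affinity to adenosine receptor A1 (Homo sapiens), read by radioligand binding (a higher number here means a weaker inhibitor, a lower number a stronger inhibitor), compound 2 gives 78 nM, the highest of the two numbers measured so far; its only neighbour is compound 1, and the step of a 1.6-fold higher number from compound 1 to compound 2 (0.19 log units; within the scatter) lies within the scatter, so the two compounds cannot be told apart on these data. Compound 3 `CC(C)/N=C(\S)OC[C@H]1OC(n2cnc3c(NC4CCOC4)ncnc32)[C@H](O)[C@@H]1O` differs from compound 2 by a group of 6 heavy atoms (4 carbon, 1 nitrogen, 1 sulfur; no ring) in place of a group of 6 heavy atoms (4 carbon, 1 nitrogen, 1 oxygen; no ring), on an oxygen on a saturated carbon. Going by the values given here, one measured step bears on this change: from compound 1 to compound 2, a group of the same kind as the one now entering was replaced by the group now leaving, and that step was a 1.6-fold higher number from compound 1 to compound 2 (0.19 log units; within the scatter). Running the same kind of swap in the opposite direction, a slightly lower number is expected for compound 3, but not one beyond the scatter. Compound 3 is therefore estimated at 55 nM, with a range from 25 nM to 120 nM. The expected step is a 1.4-fold lower number from compound 2 to compound 3 (0.15 log units; within the scatter).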

Compound 3, inhibition constant: 36 nM
For compound 3 the middle estimate is 1.5-fold (0.18 log units) above the measured one; the measured number falls inside the stated range.
By their numbers in this assay, from the lowest: compounds 3, 1 and 2 (each within the scatter of the next, the first and the last beyond it).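

In this assay, for the compounds shown here, the sulfur-bearing group in place of isopropylcarbamoyl, on an oxygen on a saturated carbon, gives a 2.2-fold lower number from compound 2 to compound 3 (0.34 log units; beyond the scatter) as a modest change, the first step here to pass beyond the scatter. Both groups carry an isopropyl, so this swap can be read with that branched chain kept in place. The other change, isopropyl in place of propyl on a double-bonded nitrogen, gives a 1.4-fold lower number from compound 1 to compound 3 (0.14 log units; within the scatter) and so leaves the two compounds indistinguishable on these data.

Nothing available here explains why the sulfur-bearing group goes with the lower number. As far as these compounds go, whether a longer chain such as butyl, or a cyclopropyl group, on that nitrogen would hold this level remains open, as does the size of the same swap on a propylcarbamoyl group.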